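The source may hold more compounds than are shown below. What is called first, only, known or untested is meant among the compounds shown, and "the series" means these compounds.

In a functional assay, read by spectrophotometry, tested at 100 uM (a higher number here means a weaker inhibitor, a lower number a stronger inhibitor), three compounds built on a shared core have been measured. Compound 1 (`O=C(/C=C/c1ccc(F)cc1)c1cccc(NC(=O)c2cc(-c3ccncc3)n[nH]2)c1`) gives 58700 nM, compound 2 (`O=C(/C=C/c1ccc(Cl)cc1)c1cccc(NC(=O)c2cc(-c3ccncc3)n[nH]2)c1`) gives 78900 nM, and compound 3 (`CN(C)c1ccc(/C=C/C(=O)c2cccc(NC(=O)c3cc(-c4ccncc4)n[nH]3)c2)cc1`) gives 60900 nM. Compound 3 therefore stands within the scatter of both others, and the three cannot be ranked. Compound 4 (`COc1cc(/C=C/C(=O)c2cccc(NC(=O)c3cc(-c4ccncc4)n[nH]3)c2)cc(OC)c1OC`) differs from compound 3 in one place, on a double-bonded chain carbon bound to a double-bonded chain carbon: 3,4,5-trimethoxyphenyl in place of 4-(dimethylamino)phenyl on a double-bonded chain carbon bound to a double-bonded chain carbon.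

Going by the values given here, three measured steps bear on this change, each a swap of one group on an aromatic carbon. They are a 1.3-fold higher number from compound 1 to compound 2 (0.13 log units; within the scatter), a 1.0-fold higher number from compound 1 to compound 3 (0.02 log units; within the scatter) and a 1.3-fold lower number from compound 2 to compound 3 (0.11 log units; within the scatter). All three lie within the scatter, so fluoro, chloro and dimethylamino have not separated in this assay. None of these steps tests a 3,4,5-trimethoxyphenyl group, however, so the evidence is indirect and the range must stay wide. On the flat steps from compound 1 and compound 2, no step beyond the scatter is expected in this assay, in either direction. The expected change is a 1.0-fold lower number from compound 3 to compound 4 (0.01 log units; within the scatter). For compound 4 the estimated value is 60000 nM, with an expected range of 30000 nM to 100000 nM.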

Compound 4, half-maximal inhibitory concentration: 52900 nM
Beside the measured number, compound 4's estimate is 1.1-fold (0.05 log units) above it; measured number inside the range.
By their numbers in this assay, from the lowest: compounds 4, 1, 3 and 2 (each within the scatter of the next).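

In this assay, going by these compounds alone, the earlier compounds only swapped a single group on an aromatic carbon, whereas compound 4 replaces the whole aryl group on a double-bonded chain carbon bound to a double-bonded chain carbon, bringing in 3,4,5-trimethoxyphenyl with more heavy atoms and more hydrogen-bond acceptors than 4-(dimethylamino)phenyl. Even so, the result is a 1.2-fold lower number from compound 3 to compound 4 (0.06 log units; within the scatter) and against the other two groups it is a 1.5-fold lower number from compound 2 to compound 4 (0.17 log units; within the scatter) and a 1.1-fold lower number from compound 1 to compound 4 (0.05 log units; within the scatter) so this larger replacement at this position does not separate compound 4 from any of the three earlier compounds, and all four remain unranked in this assay. No measured evidence accounts for this flat result.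

What the compounds shown leave open is whether any group at this position can move the number beyond the scatter in either direction, since every group here is a substituted phenyl and none carries a carboxylic acid or a primary amine. On these data alone, whether a group without an aromatic ring, such as a simple alkyl chain, would give a different number at this position also stays open.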